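The source may hold more compounds than are shown below. What is called first, only, known or untested is meant among the compounds shown, and "the series" means these compounds.

Compound 3 `COC1=C(OC)[C@H](O)[C@H](C/C=C(\C)CC/C=C(\C)C/C=C/C(C)(C)O)[C@@H](C)C1=O` has the highest number of the three compounds measured in a functional assay on A549 cells (Homo sapiens) for inhibition, read by sulforhodamine B assay, with a stated time of 48 h; a higher number here means a weaker inhibitor of growth, a lower number a stronger inhibitor of growth: compound 3 gives 23800 nM, compound 1 `COC1=C(OC)[C@H](O)[C@H](C/C=C(\C)CC/C=C(\C)C[C@@H]2C[C@@H](C)C(=O)O2)[C@@H](C)C1=O` gives 14100 nM, and compound 2 `COC1=C(OC)[C@H](O)[C@H](C/C=C(\C)CC/C=C(\C)CCC=C(C)C)[C@@H](C)C1=O` gives 5700 nM. Compound 4 `COC1=C(OC)[C@H](O)[C@H](C/C=C(\C)CC/C=C(\C)CC/C=C(\C)CO)[C@@H](C)C1=O` is built from the same atoms as compound 3, joined differently in the side chain: 3-(hydroxymethyl)but-2-en-1-yl in place of 3-hydroxy-3-methylbut-1-en-1-yl on a saturated chain carbon bound to a double-bonded chain carbon. For the measured compounds named here, two measured steps bear on this. The step of a 4.2-fold higher number from compound 2 to compound 3 (0.62 log units; beyond the scatter) introduced a hydroxyl onto the chain, while the step of a 1.7-fold higher number from compound 1 to compound 3 (0.23 log units; within the scatter) stayed within the scatter. Compound 4 resembles compound 2 more closely than compound 3 does, differing from compound 2 only by a hydroxyl, so a modest gain is expected, a 2.0-fold lower number from compound 3 to compound 4 (0.30 log units; within the scatter). Compound 4 is expected to give 12000 nM, within 5000 nM to 30000 nM.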

Compound 4, concentration for 50% growth inhibition: 8200 nM
Compound 4: middle estimate off by 1.5-fold (0.17 log units), on the high side, and the stated range covers the measured number.
By their numbers in this assay, from the lowest: compounds 2, 4, 1 and 3 (each within the scatter of the next, the first and the last beyond it).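

Same atoms, joined differently, are enough to shift the number on this saturated chain carbon: 3-(hydroxymethyl)but-2-en-1-yl in place of 3-hydroxy-3-methylbut-1-en-1-yl gives a 2.9-fold lower number from compound 3 to compound 4 (0.46 log units; beyond the scatter). Hydroxy in place of hydrogen gives a 1.4-fold higher number from compound 2 to compound 4 (0.16 log units; within the scatter), so this hydroxyl, unlike the arrangement in compound 3, leaves the number within the scatter, and the step to the ring-bearing group gives a 1.7-fold lower number from compound 1 to compound 4 (0.24 log units; within the scatter). Nothing available explains these differences. From the compounds shown here alone, whether an amine or a carboxylic acid in place of the hydroxy of compound 4 would behave alike remains open. So does the effect of a longer chain.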